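The source may report more compounds than this note shows. Statements on the series, on what has been measured and on what is new or still open speak of the compounds shown alone.

In a functional assay on MCF7 cells (Homo sapiens) for cytotoxicity (on this read-out higher numbers stand for weaker inhibition of growth and lower numbers for stronger inhibition of growth), compound 1 (`COc1ccc(NS(=O)(=O)c2c(F)c(F)c(F)c(F)c2Br)cc1`) gives 39 nM and compound 2 (`COc1ccc(NS(=O)(=O)c2c(F)c(Cl)c(F)c(Cl)c2F)cc1`) gives 37 nM as its value, so the two sit within the usual scatter of each other. Compound 3 (`COc1ccc(NS(=O)(=O)c2c(F)c(F)c(F)c(F)c2F)cc1`) has not yet been measured. It differs from compound 1 by fluoro in place of bromo on an aromatic carbon. Going by the values given here, no measured pair shows this swap alone, but compound 2 carries no bromo and gives 37 nM in the same range, so no step beyond the scatter is expected. The expected size of the change is a 1.3-fold higher number from compound 1 to compound 3 (0.11 log units; within the scatter) and no more. For compound 3 the estimated value is 50 nM with an expected range from 20 nM to 120 nM in this measurement.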

Compound 3, concentration for 50% growth inhibition: 29 nM
Estimate against measurement, compound 3: 1.7-fold (0.24 log units) above, within the range that was stated.
By their numbers in this assay, from the lowest: compounds 3, 2 and 1 (each within the scatter of the next).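

Placing fluoro instead of bromo on this aromatic carbon, ortho to a large group, gives a direct reading of this one change: in this assay it is a 1.3-fold lower number from compound 1 to compound 3 (0.13 log units; within the scatter). At this position, the read-out therefore does not separate bromo from fluoro, and the bromo is not needed to keep growth inhibition in this range. Nothing available explains why the two groups read alike. Still open, going by these compounds, is whether an amine or a carboxylic acid at this position would read the same. Also open, on these data alone, is whether this swap would read alike on a different core.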